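The source may report more compounds than this note shows. Statements on the series, on what has been measured and on what is new or still open speak of the compounds shown alone.

Compound 1 `CCCCCCCCCC(=O)O[C@H]1[C@H](O)[C@H](n2ccc(N)nc2=O)O[C@@H]1CO` gives 0.09 ug/mL in a functional assay on HeLa cells (Homo sapiens) for cytotoxicity, read by cell counting, with a stated time of 48 h (on this read-out lower numbers stand for an effect already at smaller amounts and higher numbers for an effect only at larger amounts of compound), the lowest of the three numbers in hand. Among the measured compounds shown here, compound 2 `CCCCCCCCCCCC(=O)OC[C@H]1O[C@@H](n2ccc(N)nc2=O)[C@@H](O)[C@@H]1OC(=O)CCCCCCCCCCC` gives 0.5 ug/mL in this assay and compound 3 `CCCCCCCC/C=C\CCCCCCCC(=O)OC[C@H]1O[C@@H](n2ccc(N)nc2=O)[C@@H](O)[C@@H]1OC(=O)CCCCCCC/C=C\CCCCCCCC` gives 1.1 ug/mL; both of these lie beyond the scatter above compound 1, though no single-point step connects them to it, so their numbers are only noted. Compound 4 `CCCCCCCCCCCCCCCCCC(=O)O[C@H]1[C@H](O)[C@H](n2ccc(N)nc2=O)O[C@@H]1CO` has not yet been measured. It differs from compound 1 in one place: octyl in place of hydrogen on a saturated chain carbon, nine bonds along the chain from a carbonyl carbon. For the measured compounds named here, no measured pair shows the effect of such a lengthening alone. The step of a 3.3-fold higher number from compound 1 to compound 4 (0.52 log units; beyond the scatter) is expected to be modest, toward higher numbers, perhaps just beyond the scatter. Compound 4 is therefore estimated at 0.3 ug/mL, within a range from 0.08 ug/mL to 1.5 ug/mL.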

Compound 4, concentration for half-maximal effect: 0.13 ug/mL
For compound 4 the middle estimate is 2.3-fold (0.36 log units) above the measured one; measured number inside the range.
By their numbers in this assay, from the lowest: compounds 1 and 4 (each within the scatter of the next); then compound 2; then compound 3.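

In this assay, octyl in place of hydrogen on a saturated chain carbon, nine bonds along the chain from a carbonyl carbon, gives a 1.4-fold higher number from compound 1 to compound 4 (0.16 log units; within the scatter). This first single-place pair shows that, at this position, the added carbons leave the number indistinguishable from that of compound 1. Nothing available explains this result. The compounds shown leave open whether a longer chain than this would behave the same way, and whether an amine or a carboxylic acid in place of octyl would do so.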